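The source may report more compounds than this note shows. Statements on the series, on what has been measured and on what is new or still open speak of the compounds shown alone.

Three compounds have been measured in a functional assay on MOLT-4 cells (Homo sapiens) for cytotoxicity, read by sulforhodamine B assay, with a stated time of 48 h, tested at 0.1 uM; a higher number here means a weaker effect of the compound at the concentration tested, a lower number a stronger effect:

Compound 1 `COc1cc(-c2cc(/C=C/C(=O)c3ccc(N)cc3)[nH]n2)cc(OC)c1OC`: 102%
Compound 2 `COc1ccc(C(=O)/C=C/c2cc(-c3cc(OC)c(OC)c(OC)c3)n[nH]2)cc1OC`: 98%
Compound 3 `COc1ccc(C(=O)/C=C/c2cc(-c3cc(OC)c(OC)c(OC)c3)n[nH]2)cc1`: 103%

All three values sit within the usual scatter of one another, so none of them can be told apart. Compound 4 `COc1ccc(-c2cc(/C=C/C(=O)c3ccc(N)cc3)[nH]n2)cc1OC` has not been measured yet. It differs from compound 1 by hydrogen in place of methoxy on an aromatic carbon. The same kind of change separates compound 2 from compound 3, (hydrogen in place of methoxy on an aromatic carbon), and there the step was a number 5 percentage points higher from compound 2 to compound 3 (within the scatter). The surroundings are not identical: in compound 1 the place is also meta to a methoxy group, which is not so in compound 2. The two cores differ by 4-aminophenyl in place of 3,4-dimethoxyphenyl on a carbonyl carbon. From compound 1 to compound 4 the expected step in this assay is a number 1 percentage points higher from compound 1 to compound 4 (within the scatter), resting on the step of a number 5 percentage points higher from compound 2 to compound 3 (within the scatter) and on the fact that every measured value lies near the same level. Compound 4 is therefore estimated at 103%, with a range from 93% to 113%.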

Compound 4, a percentage reported as activity, at one concentration (the size of the read-out at that concentration, not a potency): 106%
Compound 4: middle estimate off by 3 percentage points, on the low side; low and high end bracket the measured number.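

In this assay, hydrogen in place of methoxy on the aromatic ring gives a number 4 percentage points higher from compound 1 to compound 4 (within the scatter). Set beside the earlier case, the change looks the same on both cores: the same change on two cores in this assay, a number 5 percentage points higher (within the scatter) from compound 2 to compound 3 and a number 4 percentage points higher (within the scatter) from compound 1 to compound 4, 1 percentage points apart, within the scatter of two such steps

This does not show that the change carries over in any useful way: neither step can be told from the scatter, and two such steps would agree whether or not the methoxy matters in a core with a clear effect.

The compounds shown leave open whether any group at this place could give a number clearly apart from the others. A hydroxyl, a chlorine or an ethoxy there remains untested in what is shown here.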